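A few compounds are considered here, and "the series" means these few. Any claim that something is new, unique, unknown or untested is made for them only; others in the source may bear on it.

Compound 1 `CCOC(=O)c1ccc(-c2nn(Cc3ccc(Cl)cc3)c3ccccc23)cc1`: 120 nM
Compound 2 `CCCOC(=O)c1ccc(-c2nn(Cc3ccccc3)c3ccccc23)cc1`: a limit of the assay, > 10000 nM
Compound 3 `NC(=O)c1ccc(-c2nn(Cc3ccccc3)c3ccccc23)cc1`: a limit of the assay, > 10000 nM

Going by the values given here, in a functional assay on cells (Platelet, Homo sapiens) for inhibition (on this read-out higher numbers stand for weaker inhibition and lower numbers for stronger inhibition), compound 1 gives 120 nM, the only true number among the three. For compound 2 the value > 10000 nM is a limit. For compound 3 the value > 10000 nM is also a limit, so the step that the two limits leave unreadable from compound 2 to compound 3 cannot be sized, because the limit of > 10000 nM in this assay, at which 2 of the 3 values shown sit, covers both. Compound 4 `CCOC(=O)c1ccc(-c2nn(-c3ccccc3)c3ccccc23)cc1` differs from compound 1 in one place: phenyl in place of 4-chlorobenzyl on an aromatic nitrogen. No measured step touches this change, so no size or direction can be drawn from the numbers shown. A step of an 8.3-fold higher number from compound 1 to compound 4 (0.92 log units; beyond the scatter) in this assay is therefore only a guess, expected to weaken inhibition. Compound 4 is estimated at 1000 nM, between 150 nM and 10000 nM.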

Compound 4, half-maximal inhibitory concentration: 2640 nM
Beside the measured number, compound 4's estimate is 2.6-fold (0.42 log units) below it; the range from low to high includes it.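

The aromatic nitrogen of the shared core proves sensitive to what it carries in this assay: a 22-fold higher number from compound 1 to compound 4 (1.34 log units; beyond the scatter) means much weaker inhibition, though compound 4 still gives a true number and not a limit. This single change removes both the chlorine and the methylene link to the ring, so the step cannot be divided between them.

Open, on these data alone, is how a longer chain such as 2-phenylethyl, or a methyl group, on that nitrogen would fare with the ethyl ester kept. Nothing measured here explains the size of this step.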